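A few compounds are considered here, and "the series" means these few. Any claim that something is new, unique, unknown or untested is made for them only; others in the source may bear on it.

In a functional assay on SiHa cells (Homo sapiens) for inhibition, read by CCK-8 assay, with a stated time of 72 h, tested at 10 uM (on this read-out higher numbers stand for more inhibition of growth at the one concentration tested and lower numbers for less inhibition of growth), compound 1 `CN(C)C(=O)c1cc2cnc(Nc3ccc(NC(=O)C4(C(=O)Nc5ccccc5F)CC4)cc3)nc2n1C1CCCC1` gives 103%, compound 2 `CN(C)C(=O)c1cc2cnc(Nc3ccc(NC(=O)C4(C(=O)Nc5ccc(Cl)c(C(F)(F)F)c5)CC4)cc3)nc2n1C1CCCC1` gives 61.1%, and compound 3 `CN(C)C(=O)c1cc2cnc(Nc3ccc(NC(=O)C4(C(=O)Nc5ccc(O)cc5)CC4)cc3)nc2n1C1CCCC1` gives 94.3%. Compound 3 therefore stands level with compound 1 and clear of compound 2, as two steps show: a number 8.7 percentage points lower from compound 1 to compound 3 (within the scatter), and a number 33.2 percentage points higher from compound 2 to compound 3 (beyond the scatter). Compound 4 `CN(C)C(=O)c1cc2cnc(Nc3ccc(NC(=O)C4(C(=O)Nc5ccccc5)CC4)cc3)nc2n1C1CCCC1` differs from compound 3 as follows: hydrogen in place of hydroxy on an aromatic carbon. This places hydrogen in place of hydroxy on an aromatic carbon, leaving a phenyl. For the measured compounds named here, no measured step makes this exact change. The nearest evidence is the swap of 2-fluorophenyl for 4-hydroxyphenyl, a number 8.7 percentage points lower from compound 1 to compound 3 (within the scatter). The large step, a number 41.9 percentage points lower from compound 1 to compound 2 (beyond the scatter), brings in 4-chloro-3-(trifluoromethyl)phenyl, which plays no part here. No step beyond the scatter is therefore expected, and the expected change is a number 1.3 percentage points lower from compound 3 to compound 4 (within the scatter). Compound 4 is estimated at 93%, with an expected range of 74% to 106%.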

Compound 4, percent growth inhibition at one concentration: 106%
The estimate for compound 4 lay 13 percentage points below the measured number, within the range that was stated.
By their numbers in this assay, from the lowest: compound 2; then compounds 3, 1 and 4 (each within the scatter of the next, the first and the last beyond it).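

In this assay, for the compounds shown here, the bare phenyl gives the first step at this position that lies beyond the scatter, a number 11.7 percentage points higher from compound 3 to compound 4 (beyond the scatter), so the hydroxy is not needed for growth inhibition here and its removal does not reduce it. The other two steps, a number 3 percentage points higher from compound 1 to compound 4 (within the scatter) and a number 44.9 percentage points higher from compound 2 to compound 4 (beyond the scatter), place phenyl level with 2-fluorophenyl and well clear of 4-chloro-3-(trifluoromethyl)phenyl. Nothing available explains these differences. Open, as far as these compounds go, is how an amine or a carboxylic acid on an aromatic carbon of this ring would read.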